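Adding chloro to compound 3: what toxicity to expect

This account rests on a few compounds, and the source may have more. Where it says the series, first, only, none or still open, it means among the compounds named here.

In an ADME assay on BHK-21 cells (Mesocricetus auratus) for cytotoxicity, read by MTT assay (on this read-out lower numbers stand for higher toxicity in this test and higher numbers for lower toxicity in this test), compound 3 `C/C(=N\NC(N)=O)c1ccc2[nH]c(-c3ccccc3)nc2c1` gives > 100000 nM, which is a limit of the assay and not a number. Compound 3 thus sits at the limit of > 100000 nM in this assay, at which 2 of the 3 values shown sit. Compound 4 `C/C(=N\NC(N)=O)c1ccc2[nH]c(-c3ccc(Cl)cc3)nc2c1` differs from it in one place: chloro in place of hydrogen on an aromatic carbon, so that phenyl becomes 4-chlorophenyl. Within the data shown here, no measured pair shows this change directly. The nearest evidence comes from two compounds that already carry 4-chlorophenyl. Compound 1 `CC(=O)c1ccc2[nH]c(-c3ccc(Cl)cc3)nc2c1` gives > 100000 nM, which is also a limit. Among the measured compounds shown here, compound 2 `C/C(=N\O)c1ccc2[nH]c(-c3ccc(Cl)cc3)nc2c1` gives 33000 nM, the only true number among the measured compounds. Between these two lies an at least 3.0-fold lower number from compound 1 to compound 2 (0.48 log units; beyond the scatter), a step beyond the scatter, but it swaps a different group and leaves the chloro untouched. It therefore gives no size for the present change. Compound 4 shares its chloro with both, so its reading could stay level with that of compound 1. It could also fall toward the reading of compound 2 at 33000 nM. The expected change is a modest one toward higher toxicity in this test, estimated as an at least 1.6-fold lower number from compound 3 to compound 4 (0.22 log units; that floor lies within the scatter). For compound 4 the estimated value is 60000 nM, with an expected range of 20000 nM to 100000 nM.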

Compound 4, half-maximal cytotoxic concentration: > 100000 nM
Compound 4: a limit, no number; the forecaster's own chance of this, stated with the estimate: 45%; at least 1.6-fold (0.22 log units) between middle value and limit.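

In this assay compound 4 gives > 100000 nM, which is a limit of the assay and not a number. With 4-chlorophenyl kept in place, ureido in place of hydroxy on the double-bonded nitrogen gives an at least 3.0-fold higher number from compound 2 to compound 4 (0.48 log units; beyond the scatter), so the measurable toxicity of compound 2 does not carry over to compound 4, while the steps to compound 4 from compound 3 and from compound 1 cannot be read. Chloro para to a large group therefore does not bring the ureido series down into the measurable range, and compound 4 joins the compounds at the top of the scale: the limit of > 100000 nM in this assay, at which 3 of the 4 values shown sit.

How far chloro shifts the reading, if at all, stays open, as the compounds shown hold no change from phenyl to 4-chlorophenyl with a true number at both ends. Also open, as far as these compounds go, is how an amine in that same place on the phenyl, or a carboxylic acid in place of the ureido group, would read.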